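Swapping chloro for tert-butyl on compound 1's aryl ring

This account rests on a few compounds, and the source may have more. Where it says the series, first, only, none or still open, it means among the compounds named here.

Measured so far:
- compound 1, `O=C1C2=C(C(=O)c3ncccc31)C1(CS2)NC(=O)N(c2ccc(Cl)cc2)C1=O`: 2 nM
- compound 2, `O=C1NN(c2ccc(Cl)cc2)C(=O)C2(CSC3=C2C(=O)c2ncccc2C3=O)N1`: 150 nM

Among the measured compounds shown here, in a functional assay on HeLa cells (Homo sapiens) for antiproliferative activity, read by MTT assay, with a stated time of 96 h (a lower number here means a stronger inhibitor, a higher number a weaker inhibitor), compound 1 gives 2 nM, the lowest of the two numbers known. Compound 2, whose core differs, gives 150 nM in this assay, a gap well beyond the scatter. Compound 3, `CC(C)(C)c1ccc(N2C(=O)NC3(CSC4=C3C(=O)c3ncccc3C4=O)C2=O)cc1`, keeps the core of compound 1 and changes only one spot: tert-butyl in place of chloro on an aromatic carbon. For the measured compounds named here, no measured pair shows this change, so its effect is open. A modest loss is expected, a 4.0-fold higher number from compound 1 to compound 3 (0.60 log units; beyond the scatter), since compound 1 already sits very low. Compound 3 is therefore estimated at 8 nM, within 1.5 nM to 50 nM.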

Compound 3, half-maximal inhibitory concentration: 100 nM
Beside the measured number, compound 3's estimate is 13-fold (1.10 log units) below it; the whole stated range lies below it.
By their numbers in this assay, from the lowest: compound 1; then compounds 3 and 2 (each within the scatter of the next).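

In this assay, the swap from 4-chlorophenyl to 4-(tert-butyl)phenyl gives a 50-fold higher number from compound 1 to compound 3 (1.70 log units; beyond the scatter) and so shows that this spot on the aryl ring is far from indifferent to the group it carries. The earlier compounds shown here said nothing about this spot, and here a single change, with the core of compound 1 kept, is enough for a large loss. No measurement available here explains that loss. Open, on these data alone, is how fluoro, methyl, methoxy or an amine would fare in this place, and so whether chloro is unusually favourable or tert-butyl alone is poorly accepted.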